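Aryl change on the shared core: estimate for compound 3

A few compounds are considered here, and "the series" means these few. Any claim that something is new, unique, unknown or untested is made for them only; others in the source may bear on it.

Among the compounds with values here, compound 2 `CC(C)(C)n1ncc(OCc2nnc(-c3c(F)cccc3F)o2)c(Cl)c1=O` carries the only number in a functional assay on the whole organism for inhibition, with Mythimna separata as the target, with a stated time of 5 days (a higher number here means that more compound is needed for the effect, a lower number that less compound is needed), giving 45400 nM. For compound 1 `Cc1cc(C)cc(-c2nnc(COc3cnn(C(C)(C)C)c(=O)c3Cl)o2)c1` the value > 299000 nM is a limit of this assay, not a number. Within the data shown here, the one measured step is an at least 6.5-fold lower number from compound 1 to compound 2 (0.81 log units; beyond the scatter), a drop beyond the scatter. Compound 3 `CCc1ccc(-c2nnc(COc3cnn(C(C)(C)C)c(=O)c3Cl)o2)cc1` carries 4-ethylphenyl in place of 2,6-difluorophenyl on an aromatic carbon, returning to an alkyl-substituted phenyl as in compound 1, so the reverse direction is expected, a rise of at least modest size in this assay, with a limit again possible. Compound 3 is expected to give about 230000 nM, within 60000 nM to 600000 nM. The expected step is a 5.1-fold higher number from compound 2 to compound 3 (0.70 log units; beyond the scatter).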

Compound 3, half-maximal effective concentration: 14500 nM
Estimate against measurement, compound 3: 16-fold (1.20 log units) above, and the stated range ends above it.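

In this assay, an alkyl group on the phenyl does not by itself raise the number: 4-ethylphenyl in place of 2,6-difluorophenyl gives a 3.1-fold lower number from compound 2 to compound 3 (0.50 log units; beyond the scatter) at this carbon. The two alkyl-substituted phenyls also differ widely, with an at least 20-fold lower number from compound 1 to compound 3 (1.31 log units; beyond the scatter) and so the kind of alkyl substitution counts, not its presence alone. That step starts from a limit of the assay for compound 1, not a number: the limit of > 299000 nM in this assay, at which 1 of the 3 values shown sits.

Going by these compounds, whether the ethyl group itself or its place on the phenyl drives the lower number stays open. Also open, on these data alone, is how a longer chain or an amine in place of the ethyl group would read here.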